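The source may hold more compounds than are shown below. What is called first, only, known or untested is meant among the compounds shown, and "the series" means these compounds.

Working notes on the series.

Two compounds in this set have a number in an assay on HEK293 cells for agonist activity at transient receptor potential cation channel subfamily M member 8 (Homo sapiens), read by fluorescence and calcium flux, with a stated time of 15 min; on this read-out lower numbers stand for an effect already at smaller amounts and higher numbers for an effect only at larger amounts of compound. Compound 1 `Cc1ccc(OCC(=O)N(Cc2cccs2)c2ncco2)cc1` gives in this assay a value of 0.3 nM and stands at the lowest of the two numbers. Compound 2 `CCN(Cc1ccc(C)s1)C(=O)COc1ccc(C)cc1` gives in this assay a value of 178 nM; the two structures differ in more than one place, so only the two values themselves can be compared, and the gap between them lies well beyond the usual scatter.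

Compound 3 `Cc1ccc(OCC(=O)N(Cc2cccs2)c2cnn(C)c2)cc1` is not yet measured. Against compound 1 the change is 1-methyl-1H-pyrazol-4-yl in place of 1,3-oxazol-2-yl on an amide-type nitrogen. Going by the values given here, no measured pair shows the effect of swapping a heteroaryl group on this amide-type nitrogen, so the size of the step cannot be read from the data; a step in this assay toward a higher number, beyond the scatter, is the expectation, since the heteroaryl group on the amide-type nitrogen is part of what separates compound 1 from compound 2.

For compound 3 the estimated value in this assay is 5 nM, with a range from 0.5 nM to 50 nM, which means an expected step of a 17-fold higher number from compound 1 to compound 3 (1.22 log units; beyond the scatter).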

Compound 3, half-maximal effective concentration: 63000 nM
For compound 3 the middle estimate is 13000-fold (4.10 log units) below the measured one, and the stated range ends below it.
By their numbers in this assay, from the lowest: compound 1; then compound 2; then compound 3.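

In this assay, going by these compounds alone, 1-methyl-1H-pyrazol-4-yl in place of 1,3-oxazol-2-yl on the amide-type nitrogen gives a 210000-fold higher number from compound 1 to compound 3 (5.32 log units; beyond the scatter) and provides the first one-place comparison. The result shows that this position, on a nitrogen whose other neighbours are the carbonyl carbon and a saturated chain carbon, tolerates very little change in this read-out: both groups are five-membered aromatic rings with 2 hetero atoms, 0 hydrogen-bond donors, 2 hydrogen-bond acceptors and no net charge, so these shared counts do not make the two groups interchangeable here. No measurement available for the series accounts for the size of this step.

Within the data shown here, the single step does not separate the contribution of the methyl group from that of the ring itself or its point of attachment, so the unmethylated 1H-pyrazol-4-yl group would be informative on the first question and 1-methyl-1H-pyrazol-3-yl on the second. It also leaves open how narrowly the low number of compound 1 depends on 1,3-oxazol-2-yl, a question that close relatives such as 1,3-thiazol-2-yl or 1,3-oxazol-4-yl at the same nitrogen would address.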